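The source may hold more compounds than are shown below. What is called first, only, known or untested is meant among the compounds shown, and "the series" means these compounds.

Among the compounds with values here, compound 2 `O=C(NCCCCCCCn1cc(-c2cccnc2)nn1)c1ccccc1-n1ccnn1` holds the only measured number in this set: in an assay for inhibition of Nicotinamide phosphoribosyltransferase (Mus musculus), read by fluorescence, with a stated time of 1 h, in the presence of a further agent that is not named here (a lower number here means a stronger inhibitor, a higher number a weaker inhibitor), compound 2 gives 3.4 nM as its result. Compound 1 `O=C(O)c1ccc(-c2ccccc2C(=O)NCCCCCCCn2cc(-c3cccnc3)nn2)cc1` in this assay gives > 500 nM as a limit of the assay rather than a number. Within the data shown here, the single measured step, an at least 140-fold lower number from compound 1 to compound 2 (2.16 log units; beyond the scatter), changes the group on the benzene ring. Compound 3 `O=C(NCCCCCCCn1cc(-c2cccnc2)nn1)c1ccccc1-n1cc(CN2CCC(O)CC2)nn1` differs from compound 2 at another place, by (4-hydroxypiperidin-1-yl)methyl in place of hydrogen on an aromatic carbon on the five-membered ring. That earlier step does not touch this position, so no change beyond the scatter is expected, a 1.2-fold higher number from compound 2 to compound 3 (0.07 log units; within the scatter) in size. Compound 3 is therefore estimated at 4 nM, ranging from 1.2 nM to 15 nM in this assay.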

Compound 3, half-maximal inhibitory concentration: 41.8 nM
Compound 3: middle estimate off by 10-fold (1.02 log units), on the low side; measured number above the stated range.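

This aromatic carbon of the five-membered ring is not a place where a group can be added without consequence: (4-hydroxypiperidin-1-yl)methyl brings a 12-fold higher number from compound 2 to compound 3 (1.09 log units; beyond the scatter). So far only replacing the whole group on the benzene ring had moved the number, and now a change on the five-membered ring itself does too. Nothing measured here explains this rise. On these data alone, whether it follows from the piperidine ring or its hydroxyl remains open. So does whether a methyl, a dimethylaminomethyl or a carboxylic acid on this carbon would behave the same way.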